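Trading Methoxy for Two Fluorines on the Carbonyl-Bound Ring

The source may report more compounds than this note shows. Statements on the series, on what has been measured and on what is new or still open speak of the compounds shown alone.

Compound 2 `COc1ccc(C(=O)/C=C/c2cc(-c3cc(OC)c(OC)c(OC)c3)n[nH]2)cc1` was tested in a functional assay on M14 cells (Homo sapiens) for inhibition, read by sulforhodamine B assay, with a stated time of 48 h; a lower number here means that less compound is tolerated, a higher number that more compound is tolerated. In this assay compound 2 reaches only the limit of > 100000 nM, so no exact number is known for it. Among the compounds with values here, its single measured neighbour is compound 1 `COc1cc(-c2cc(/C=C/C(=O)c3ccc(N)cc3)[nH]n2)cc(OC)c1OC`, which in this assay gives 8170 nM. The step of an at least 12-fold higher number from compound 1 to compound 2 (1.08 log units; beyond the scatter) shows that exchanging one small group on the ring attached to the carbonyl carbon can shift the number a great deal, and compound 2 stands at the limit of > 100000 nM in this assay, at which 1 of the 2 values shown sits.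

Compound 3 `COc1cc(-c2cc(/C=C/C(=O)c3ccc(F)c(F)c3)[nH]n2)cc(OC)c1OC` differs from compound 2 by 3,4-difluorophenyl in place of 4-methoxyphenyl on a carbonyl carbon. Within the data shown here, no measured step involves fluorine, so the size and direction of this change are uncertain; the one measured exchange on that ring was large. For compound 3 the expected value is 40000 nM, between 8000 nM and 200000 nM. That corresponds to an expected step of an at least 2.5-fold lower number from compound 2 to compound 3 (0.39 log units; beyond the scatter), with a real chance that only a limit is reported.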

Compound 3, concentration lethal to 50% of the cells: > 100000 nM
Compound 3 was reported as a limit; the forecaster's own chance of this, stated with the estimate: 40%; middle value at least 2.5-fold (0.39 log units) from the limit.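

In this assay, the 3,4-difluorophenyl group on the carbonyl carbon leaves compound 3 at the same limit as the 4-methoxyphenyl group leaves compound 2, so the step between these two cannot be read and neither group can be ranked over the other. Set against the 4-aminophenyl group, the exchange gives an at least 12-fold higher number from compound 1 to compound 3 (1.08 log units; beyond the scatter), so a second, different replacement of the amino-bearing ring also ends without an exact number. Of the compounds shown, only compound 1 gives an exact number, and the other two now share one reading: the limit of > 100000 nM in this assay, at which 2 of the 3 values shown sit.

Going by these compounds, how much of the change is tied to the amine itself stays open, and a hydroxyl group or a dimethylamino group on this ring could test that. Nothing shown tells how far compound 2 and compound 3 lie beyond their limit.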